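The source may hold more compounds than are shown below. What is called first, only, known or untested is meant among the compounds shown, and "the series" means these compounds.

The measured compounds:
Compound 1 `CNc1cc(C)c2cc(NC(=O)c3ccc(Cl)c(Cl)c3)ccc2n1` gives 6350 nM in a functional assay on SK-BR-3 cells (Homo sapiens) for antiproliferative activity, read by MTT assay, with a stated time of 72 h; a lower number here means a stronger inhibitor, a higher number a weaker inhibitor.
Compound 2 `CCN1CCN(c2cc(C)c3cc(NC(=O)c4ccccc4F)ccc3n2)CC1` gives 38100 nM in this assay.
Compound 3 `CCN1CCN(c2cc(C)c3cc(NC(=O)c4ccccc4Br)ccc3n2)CC1` gives 39200 nM in this assay.

Compound 1 holds the lowest number of the three, and the gaps to compound 2 and to compound 3 both lie beyond the scatter. The only step measured between two of these compounds is a 1.0-fold higher number from compound 2 to compound 3 (0.01 log units; within the scatter), which swaps a halogen on the benzamide while the piperazine is kept; it does not touch the change now in question. Compound 4 `Cc1cc(N2CCN(C)CC2)nc2ccc(NC(=O)c3ccc(Cl)c(Cl)c3)cc12` differs from compound 1 by 4-methylpiperazin-1-yl in place of methylamino on an aromatic carbon. Within the data shown here, no measured pair isolates this change. Compound 2 and compound 3, which carry a piperazine in this position, give higher numbers than compound 1, but they also carry a different benzamide, so the two changes cannot be separated. The expectation is therefore a moderate rise in this assay with wide uncertainty, a step of a 1.9-fold higher number from compound 1 to compound 4 (0.28 log units; within the scatter). Compound 4 is estimated at 12000 nM, between 3000 nM and 45000 nM.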

Compound 4, half-maximal inhibitory concentration: 6320 nM
Compound 4: middle estimate off by 1.9-fold (0.28 log units), on the high side, within the range that was stated.
By their numbers in this assay, from the lowest: compounds 4 and 1 (each within the scatter of the next); then compounds 2 and 3 (each within the scatter of the next).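

In this assay, the step to 4-methylpiperazin-1-yl on the aromatic carbon next to the ring nitrogen, with the rest of compound 1 kept, is a 1.0-fold lower number from compound 1 to compound 4 (0.00 log units; within the scatter) and so separates this change from the benzamide change that compound 2 and compound 3 also carry. With the benzamide of compound 1 in place, this position accepts seven heavy atoms instead of two, and the loss of the hydrogen-bond donor of methylamino, with no difference beyond the scatter. No evidence is at hand that would explain this result.

The compounds shown leave open whether a morpholine ring or a longer aminoalkyl chain at this position would give a similar number. They also leave open how the benzamide substituents alone compare when the 4-methylpiperazin-1-yl group is held constant.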